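Anilide variation on a triazole carboxamide

The source may report more compounds than this note shows. Statements on the series, on what has been measured and on what is new or still open speak of the compounds shown alone.

Compounds measured so far:
compound 1 `CCNC(=O)c1nc(-c2cc(OC)c(OC)c(OC)c2)n(-c2ccc(OC)cc2)n1` 88%
compound 2 `COc1ccc(-n2nc(C(=O)Nc3ccccc3OC)nc2-c2cc(OC)c(OC)c(OC)c2)cc1` 38%

In a functional assay on the whole organism for inhibition, with Rattus norvegicus as the target, read by paw edema, with stated times of 30 min and 3 h, at a dose of 0.28 mmol/kg by the oral route (on this read-out higher numbers stand for more inhibition at the one dose given (going by the name of the read-out) and lower numbers for less inhibition), compound 1 gives 88%. Within the data shown here, compound 2 gives the lowest of the two numbers in this assay, 38%, and the only recorded step is a number 50 percentage points lower from compound 1 to compound 2 (beyond the scatter). Compound 3 `COc1ccc(-n2nc(C(=O)Nc3ccc(C(F)(F)F)cc3)nc2-c2cc(OC)c(OC)c(OC)c2)cc1` differs from compound 2 by 4-(trifluoromethyl)phenyl in place of 2-methoxyphenyl on an amide-type nitrogen. Among the measured compounds shown here, no measured step exchanges one aryl group on that nitrogen for another, so the recorded step does not bear directly on this change. Compound 3 is therefore expected to stay near compound 2, with a step of a number 2 percentage points higher from compound 2 to compound 3 (within the scatter) that is within the scatter. The estimate for compound 3 is 40%, between 15% and 65%.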

Compound 3, a percentage reported as inhibition, in the whole organism at one dose (the size of the read-out at that dose, not a potency): 83%
The estimate for compound 3 lay 43 percentage points below the measured number, outside the stated range (above it).
By their numbers in this assay, from the lowest: compound 2; then compounds 3 and 1 (each within the scatter of the next).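

On this amide-type nitrogen, the choice of aryl group decides the result in this assay: 4-(trifluoromethyl)phenyl in place of 2-methoxyphenyl gives a number 45 percentage points higher from compound 2 to compound 3 (beyond the scatter). With 4-(trifluoromethyl)phenyl in place of ethyl there is a number 5 percentage points lower from compound 1 to compound 3 (within the scatter), so an aryl group on this nitrogen need not lower the number. No measurement available here accounts for the difference between the two aryl groups.

The compounds shown leave open whether the step follows the loss of the methoxy group or the arrival of the trifluoromethyl group. On these data alone, it also remains open how an unsubstituted phenyl or a longer chain such as butyl on this nitrogen would read.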